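Second methyl on the aromatic ring: compound 3 outlook

This account rests on a few compounds, and the source may have more. Where it says the series, first, only, none or still open, it means among the compounds named here.

Measured so far:
compound 1 `COC(=O)[C@@]1(C)CCC=C2[C@@H]1CC[C@@H](C)[C@]2(C)Cc1c[nH]c2ccc(C)cc12`: 14000 nM
compound 2 `COC(=O)[C@@]1(C)CCC=C2[C@@H]1CC[C@@H](C)[C@]2(C)Cc1c(C)[nH]c2ccccc12`: 11000 nM

In a functional assay on HeLa cells (Homo sapiens) for inhibition, read by sulforhodamine B assay, with a stated time of 48 h (a lower number here means a stronger inhibitor of growth, a higher number a weaker inhibitor of growth), compound 1 gives 14000 nM. Compound 2 gives 11000 nM in this assay; this stands at the low end of the two numbers, though its gap to compound 1 lies within the scatter, so the two are not separated by the data. Compound 3 `COC(=O)[C@@]1(C)CCC=C2[C@@H]1CC[C@@H](C)[C@]2(C)Cc1c(C)[nH]c2ccc(C)cc12` is not yet measured. It differs from compound 2 by methyl in place of hydrogen on an aromatic carbon. Among the measured compounds shown here, no step between two measured compounds covers this change, and the two measured values give no direction for it. In this assay a step beyond the scatter is therefore not expected, in either direction. The step estimated from compound 2 to compound 3 is a 1.1-fold lower number from compound 2 to compound 3 (0.04 log units; within the scatter). Compound 3 is expected to give 10000 nM, with a range from 4000 nM to 25000 nM.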

Compound 3, concentration for 50% growth inhibition: 17000 nM
Beside the measured number, compound 3's estimate is 1.7-fold (0.23 log units) below it; the range from low to high includes it.
By their numbers in this assay, from the lowest: compounds 2, 1 and 3 (each within the scatter of the next).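

In this assay the methyl on an aromatic carbon of the six-membered ring, meta to a fused ring and para to a fused ring, gives a 1.5-fold higher number from compound 2 to compound 3 (0.19 log units; within the scatter) and stays within the scatter. Among the compounds shown here, the other single methyl step, also on an aromatic carbon, gives a 1.2-fold higher number from compound 1 to compound 3 (0.08 log units; within the scatter) and also stays within the scatter, so neither step separates the compounds it joins, and methyl in place of hydrogen has no direction in this assay so far. No measurement at hand accounts for either step.

On these data alone, whether any group at this carbon can move the number beyond the scatter stays open, for example a methoxy group, a chlorine atom, an amine or a carboxylic acid. Also open, as far as these compounds go, is whether a carboxylic acid or an amide in place of the methyl ester on the shared core would do so.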